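The source may hold more compounds than are shown below. What is called first, only, known or untested is meant among the compounds shown, and "the series" means these compounds.

Compound 2 `O=[N+]([O-])c1ccc(NC(=S)Nc2cccc(C(F)(F)F)c2)cc1` gives 10000 nM in an ADME assay on Vero 76 cells (Chlorocebus sabaeus) for cytotoxicity, read by crystal violet staining, with a stated time of 96 h (on this read-out lower numbers stand for higher toxicity in this test and higher numbers for lower toxicity in this test), and of the two numbers measured it sits alongside compound 1 `FC(F)(F)c1cccc(NC(=S)Nc2ccc(I)cc2)c1`, which gives 9500 nM, the two within the scatter of one another. Going by the values given here, the single step measured, a 1.1-fold higher number from compound 1 to compound 2 (0.02 log units; within the scatter), swapped one group for another at that position and did not move the read-out beyond the scatter. Compound 3 `Fc1ccc(NC(=S)Nc2cccc(C(F)(F)F)c2)cc1` carries the change (fluoro in place of nitro on an aromatic carbon). Among the compounds with values here, since the only comparable step, a 1.1-fold higher number from compound 1 to compound 2 (0.02 log units; within the scatter), was flat, no step beyond the scatter is expected here. Compound 3 is therefore estimated at 10000 nM in this assay, ranging from 5000 nM to 20000 nM, an expected step of no change at the digits printed from compound 2 to compound 3 (within the scatter).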

Compound 3, half-maximal cytotoxic concentration: 40000 nM
For compound 3 the middle estimate is 4.0-fold (0.60 log units) below the measured one, outside the stated range (above it).
By their numbers in this assay, from the lowest: compounds 1 and 2 (each within the scatter of the next); then compound 3.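

In this assay this position proves sensitive to its group after all: fluoro in place of nitro gives a 4.0-fold higher number from compound 2 to compound 3 (0.60 log units; beyond the scatter), and fluoro in place of iodo gives a 4.2-fold higher number from compound 1 to compound 3 (0.62 log units; beyond the scatter). Nitro and iodo stood within the scatter of each other, so fluoro alone separates from them, towards lower toxicity in this test. No evidence at hand accounts for this difference. From the compounds shown here alone, whether an amine, a methoxy group or chloro at this position would group with fluoro or with nitro and iodo remains open.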